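The compounds below may be only part of what the source reports. "The series", "measured", "known", "first", "only" and "open" are said of these compounds alone.

Compound 1 `CCc1nnc(-c2ccc(-c3ccccc3)cn2)n1-c1ccccc1F`: 700 nM
Compound 2 `CCc1nnc(N2CCC(c3ccccc3)CC2)n1-c1ccccc1F`: 3700 nM
Compound 3 `CCc1nnc(-c2ccc(-c3ccccc3)cc2)n1-c1cccc(COC)c1C`: 2400 nM

All three compounds were tested in an assay on C6 glioma cells for displacement of a labelled ligand from sodium- and chloride-dependent glycine transporter 1 (Rattus norvegicus), read by scintillation counting, with stated times of 30 min and 10 min; a lower number here means a stronger inhibitor, a higher number a weaker inhibitor. Compound 3 gives the second highest of the three numbers. Its nearest neighbour is compound 2, whose value of 3700 nM lies within the scatter of repeated measurements, so no order can be read between these two. Compound 1, which gives 700 nM, stands furthest away, with a lower number than compound 3 by a margin beyond the scatter.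

Compound 4 `CCc1nnc(-c2ccc(-c3ccccc3)cc2)n1-c1cccc(C(N)=O)c1C` has not yet been measured. It differs from compound 3 in one place: carbamoyl in place of methoxymethyl on an aromatic carbon. Among the compounds with values here, no measured pair in this set shows the effect of such a change, so there is no step to lean on, and nothing in the data points either way. The expected step is therefore no change at the digits printed from compound 3 to compound 4 (within the scatter), which is no larger than the scatter itself would allow in either direction. On that basis compound 4 is expected to give about 2400 nM in this assay, with a likely range from 700 nM to 8000 nM once the measurement is in hand.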

Compound 4, half-maximal inhibitory concentration: 3900 nM
Estimate against measurement, compound 4: 1.6-fold (0.21 log units) below, and the stated range covers the measured number.
By their numbers in this assay, from the lowest: compound 1; then compounds 3, 2 and 4 (each within the scatter of the next).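

In this assay the step is a 1.6-fold higher number from compound 3 to compound 4 (0.21 log units; within the scatter), so carbamoyl and methoxymethyl on this aromatic carbon, ortho to a methyl group, cannot be told apart. This is the first pair shown that differs in one place, and it gives the first direct reading at this position: a group with a hydrogen-bond donor stands in place of one without, and a double bond outside aromatic rings enters, yet the step stays within the scatter. No measurement shown bears on the reason for this result.

This single pair leaves open whether the position would read the same with an amine, a carboxylic acid or a longer ether chain on this carbon, since only these two groups can be set side by side here. It also leaves open whether carbamoyl in place of methoxymethyl would give a similar step on the core of compound 1 or of compound 2, or with a group other than methyl ortho to it.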